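This account rests on a few compounds, and the source may have more. Where it says the series, first, only, none or still open, it means among the compounds named here.

In an ADME assay on MT4 cells (Homo sapiens) for cytotoxicity, read by MTT assay (on this read-out higher numbers stand for lower toxicity in this test and lower numbers for higher toxicity in this test), three members of this series have been measured. Compound 1 `O=C(CSc1nnnn1-c1cccc2ccccc12)N/N=C/c1ccccc1F` gives only a limit of the test, >= 118000 nM, so its number is not readable (the limit of >= 118000 nM in this assay, at which 1 of the 3 values shown sits). Compound 2 `Cc1cccc(/C=N/NC(=O)CSc2nnnn2-c2cccc3ccccc23)c1` gives 269000 nM, and compound 3 `COc1ccc(/C=N/NC(=O)CSc2nnnn2-c2cccc3ccccc23)c(OC)c1` gives 28300 nM. Compound 3 thus holds the lowest of the two readable numbers, with a 9.5-fold lower number from compound 2 to compound 3 (0.98 log units; beyond the scatter) as the step to it from the nearest neighbour.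

Compound 4 `COc1ccc(O)c(/C=N/NC(=O)CSc2nnnn2-c2cccc3ccccc23)c1` is yet to be measured; it differs from compound 3 by 2-hydroxy-5-methoxyphenyl in place of 2,4-dimethoxyphenyl on a carbon with a double bond to nitrogen. Two measured steps change the same aryl group on that carbon: an at least 4.1-fold lower number from compound 1 to compound 3 (0.62 log units; beyond the scatter) and a 9.5-fold lower number from compound 2 to compound 3 (0.98 log units; beyond the scatter); the third, a step that the limit leaves unreadable from compound 1 to compound 2, is hidden by the limit. Both readable swaps of this ring moved the number by modest amounts, and the 2,4-dimethoxyphenyl ring sits at the low end of what has been seen, so the new ring, which keeps two oxygens but brings a hydrogen-bond donor, is expected to shift the number back upward by a small to modest step. Compound 4 is therefore expected to show a 1.8-fold higher number from compound 3 to compound 4 (0.25 log units; within the scatter). Compound 4 is estimated at 50000 nM, between 15000 nM and 160000 nM.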

Compound 4, half-maximal cytotoxic concentration: 4510 nM
Estimate against measurement, compound 4: 11-fold (1.04 log units) above, and the stated range ends above it.
By their numbers in this assay, from the lowest: compound 4; then compound 3; then compound 2.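

In this assay, the 2,4-dimethoxyphenyl ring does not mark the low end for this place on a carbon with a double bond to nitrogen: putting 2-hydroxy-5-methoxyphenyl there gives a 6.3-fold lower number from compound 3 to compound 4 (0.80 log units; beyond the scatter). Against the other rings the gaps widen to a 60-fold lower number from compound 2 to compound 4 (1.78 log units; beyond the scatter) and an at least 26-fold lower number from compound 1 to compound 4 (1.41 log units; beyond the scatter), so this one position now spans large steps toward higher toxicity in this test, where only modest steps could be read before. Compound 1 gives a limit of the assay and not a number, so the second of those two steps is a bound only: the limit of >= 118000 nM in this assay, at which 1 of the 4 values shown sits.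

The single change from 2,4-dimethoxyphenyl to 2-hydroxy-5-methoxyphenyl both brings in a hydroxy group with its hydrogen-bond donor and alters the methoxy pattern on the ring, and the compounds shown do not separate these two parts of the swap. They also leave open how the number would respond to an amine or a carboxylic acid in place of the hydroxy group on this ring, and whether the same swap would give a step of similar size on a different core.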